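This account rests on a few compounds, and the source may have more. Where it says the series, first, only, none or still open, it means among the compounds named here.

Working notes on the series. Three compounds on the shared core have numbers in a functional assay on KB cells (Homo sapiens) for inhibition; on this read-out lower numbers stand for stronger inhibition and higher numbers for weaker inhibition. Compound 1 (`COC[C@H]1O[C@@H](n2c(Cl)nc3cc(Cl)c(Cl)cc32)[C@H](OC(C)=O)[C@@H]1OC(C)=O`) gives 80000 nM. Compound 2 (`CCOC[C@H]1O[C@@H](n2c(Cl)nc3cc(Cl)c(Cl)cc32)[C@H](OC(C)=O)[C@@H]1OC(C)=O`) gives 60000 nM. Compound 3 (`CC(=O)OC1C(CF)OC(n2c(Cl)nc3cc(Cl)c(Cl)cc32)C1OC(C)=O`) gives 100000 nM, which lies within the scatter of both compound 1 and compound 2, so the numbers do not separate these three compounds.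

The next compound is compound 4 (`CC(=O)OC1C(CCl)OC(n2c(Cl)nc3cc(Cl)c(Cl)cc32)C1OC(C)=O`), which differs from compound 3 by chloro in place of fluoro on a saturated chain carbon bound to a saturated ring carbon. In other words, fluoromethyl becomes chloromethyl.

Among the measured compounds shown here, no measured step exchanges one halogen for another, so direct evidence for this change is lacking. For the measured compounds named here, the only measured step is a 1.3-fold lower number from compound 1 to compound 2 (0.12 log units; within the scatter), and it bears on the change only loosely, as a small alteration of the same side chain that stays within the scatter. On that basis, no shift beyond the scatter is expected, and the expected step is a 1.3-fold lower number from compound 3 to compound 4 (0.10 log units; within the scatter). For compound 4 the estimated value is 80000 nM, with an expected range from 35000 nM to 150000 nM.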

Compound 4, half-maximal inhibitory concentration: 90000 nM
Compound 4: the middle estimate sits 1.1-fold (0.05 log units) below what was measured; measured number inside the range.
By their numbers in this assay, from the lowest: compounds 2, 1, 4 and 3 (each within the scatter of the next).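

In this assay, among the compounds shown here, chloro in place of fluoro on a saturated chain carbon bound to a saturated ring carbon gives a 1.1-fold lower number from compound 3 to compound 4 (0.05 log units; within the scatter), which is the only step that exchanges one halogen for another. For the compounds shown here, this supplies the direct reading that the earlier compounds lacked: at this place, the numbers do not separate fluoromethyl from chloromethyl, and this pair adds a second step within the scatter to the one between the two ether side chains. No measurement accompanies these values that could account for the result, so the step stands as a bare observation on this pair of compounds.

The compounds shown leave open whether any group in this place gives a number beyond the scatter, as they offer no reading for bromomethyl, aminomethyl, hydroxymethyl or a carboxylic acid, or for a chain longer than the ethoxymethyl of compound 2. They also leave open whether the halogen exchange would read the same on a core carrying free hydroxyl groups in place of the two acetyl esters, since all four compounds carry those esters.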